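The source may hold more compounds than are shown below. What is called first, only, known or untested is meant among the compounds shown, and "the series" means these compounds.

Working notes on the series. Compound 2 `CCN(CC)CCCOc1cc2ncnc(Nc3nc4ccc(C(=O)Nc5c(C)cccc5C)cc4s3)c2cc1OC` carries a diethylamino group at the end of the chain; compound 1 `COc1cc2c(Nc3nc4ccc(C(=O)Nc5c(C)cccc5C)cc4s3)ncnc2cc1OCCCN1CCCC1` differs by pyrrolidin-1-yl in place of diethylamino on a saturated chain carbon, three bonds along the chain from an oxygen on an aromatic ring. In a functional assay on A549 cells (Homo sapiens) for cytotoxicity, read by WST assay, with a stated time of 72 h (on this read-out lower numbers stand for stronger inhibition and higher numbers for weaker inhibition), compound 2 gives only a limit, > 100000 nM. In this assay compound 1 gives 83800 nM, so the step is an at least 1.1-fold lower number from compound 2 to compound 1 (0.07 log units; that floor lies within the scatter). Compound 3 `CCN(CC)CCCOc1cc2ncnc(Nc3nc4ccc(C(=O)Nc5c(C)cccc5Cl)cc4s3)c2cc1OC` differs from compound 2 by chloro in place of methyl on an aromatic carbon; in this assay compound 3 gives 10600 nM, a step of an at least 9.4-fold lower number from compound 2 to compound 3 (0.97 log units; beyond the scatter). Compound 4 `COc1cc2c(Nc3nc4ccc(C(=O)Nc5c(C)cccc5Cl)cc4s3)ncnc2cc1OCCCN1CCCC1`, not yet measured, differs from compound 3 by pyrrolidin-1-yl in place of diethylamino on a saturated chain carbon, three bonds along the chain from an oxygen on an aromatic ring, the same change that separates compound 2 from compound 1, with the place described in identical terms. That earlier step started from the limit given by the limit of > 100000 nM in this assay, at which 1 of the 3 values shown sits. For compound 4 a step of about a 1.2-fold lower number from compound 3 to compound 4 (0.07 log units; within the scatter) is expected, resting on compound 3 at 10600 nM. Compound 4 is estimated at 9000 nM, from 3000 nM to 30000 nM.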

Compound 4, half-maximal inhibitory concentration: 38600 nM
Compound 4: middle estimate off by 4.3-fold (0.63 log units), on the low side; measured number outside the range, above it.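

Carried to the core of compound 3 in this assay, pyrrolidin-1-yl in place of diethylamino gives a 3.6-fold higher number from compound 3 to compound 4 (0.56 log units; beyond the scatter), so the change does not transfer unaltered from the core of compound 2: the same change on two cores in this assay, an at least 1.1-fold lower number (0.07 log units; that floor lies within the scatter) from compound 2 to compound 1 and a 3.6-fold higher number (0.56 log units; beyond the scatter) from compound 3 to compound 4, at least 4.3-fold (0.63 log units) apart, beyond the scatter of two such steps. Chloro in place of methyl lowers the number on both sides, with a 2.2-fold lower number from compound 1 to compound 4 (0.34 log units; beyond the scatter), but the size does not carry over: the same change on two cores in this assay, an at least 9.4-fold lower number (0.97 log units; beyond the scatter) from compound 2 to compound 3 and a 2.2-fold lower number (0.34 log units; beyond the scatter) from compound 1 to compound 4, at least 4.3-fold (0.63 log units) apart, beyond the scatter of two such steps. Compound 2 gives only a limit, so both earlier steps are bounded rather than fixed, and two pairs set no rule for other cores: the limit of > 100000 nM in this assay, at which 1 of the 4 values shown sits.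

Open, going by these compounds, is whether piperidin-1-yl or morpholin-4-yl in place of diethylamino would follow compound 3 or compound 4. Also open, on these data alone, is whether bromo in place of chloro would keep the same order between the two amines.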